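Bromo-to-chloro swap on a second core: expected outcome

The compounds below may be only part of what the source reports. "The series", "measured", "known", "first", "only" and "open" are said of these compounds alone.

Two cores carry the same pair of halogen analogues. Compound 1 `COc1ccc(C2=NN(C3=NC(=O)/C(=C4\C(=O)Nc5ccc(Br)cc54)S3)C(c3ccc(OC)cc3)C2)cc1` and compound 2 `COc1ccc(C2=NN(C3=NC(=O)/C(=C4\C(=O)Nc5ccc(Cl)cc54)S3)C(c3ccc(OC)cc3)C2)cc1` share one core; compound 3 `CN(C)c1ccc(C2CC(c3ccccc3)=NN2C2=NC(=O)/C(=C3\C(=O)Nc4ccc(Br)cc43)S2)cc1` and compound 4 `CN(C)c1ccc(C2CC(c3ccccc3)=NN2C2=NC(=O)/C(=C3\C(=O)Nc4ccc(Cl)cc43)S2)cc1` share the other. How the two cores differ is not broken down here.

In a functional assay on cells (Leukemia cell, Homo sapiens) for cytotoxicity, read by sulforhodamine B assay, with a stated time of 48 h (on this read-out higher numbers stand for weaker inhibition of growth and lower numbers for stronger inhibition of growth), compound 1 gives 280 nM. Compound 2 gives 280 nM in this assay. The change from compound 1 to compound 2 is chloro in place of bromo on an aromatic carbon, and the step it made was no change at the digits printed from compound 1 to compound 2 (within the scatter).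

Compound 3 gives 310 nM in this assay. Its value and those of compound 1 and compound 2 all lie within the scatter of one another, so no order is drawn among the three measured compounds.

The change from compound 3 to compound 4 is chloro in place of bromo on an aromatic carbon. Its place line matches that of the earlier change word for word, so this is the same change made on a different core. Within the data shown here, the only measured instance of it gave no shift beyond the scatter, and nothing in the three measured values points to the halogen mattering on either core.

For compound 4 the step of no change at the digits printed from compound 3 to compound 4 (within the scatter) is expected, resting on the step from compound 1 to compound 2 and on compound 3 giving 310 nM. Compound 4 is estimated at 310 nM in this assay, with the usual scatter placing it between 150 nM and 650 nM.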

Compound 4, concentration for 50% growth inhibition: 340 nM
The estimate for compound 4 lay 1.1-fold (0.04 log units) below the measured number; low and high end bracket the measured number.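

In this assay the chloro-for-bromo change on the second core gives a 1.1-fold higher number from compound 3 to compound 4 (0.04 log units; within the scatter), and set beside the first core, the change carries over with no difference that can be read: the same change on two cores in this assay, no change at the digits printed (within the scatter) from compound 1 to compound 2 and a 1.1-fold higher number (0.04 log units; within the scatter) from compound 3 to compound 4, 1.1-fold (0.04 log units) apart, within the scatter of two such steps. In these two matched pairs, then, bromo and chloro on this aromatic carbon can be exchanged on either core without a step beyond the scatter in this assay. This does not show that the halogen is unimportant at this place, since both steps compare one halogen with another and say nothing of what either contributes relative to a plain hydrogen, and two pairs cannot establish how the change behaves on further cores or in other assays.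

Still open, as far as these compounds go, is whether this aromatic carbon accepts groups other than these two halogens, such as an amine or a carboxylic acid, with values staying in the same range. Among these compounds, also open is what each structural difference between the two cores contributes, as compound 1 and compound 3 differ in more than one place and no single-place step connects them.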